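The compounds below may be only part of what the source reports. "The series", "measured", "known", "first", "only" and "open" are said of these compounds alone.

Compound 1 `COc1ccc(-c2cc(/C=C/C(=O)c3ccc(Cl)cc3)nc3cc(-c4ccccc4)nn23)cc1OC`: 17100 nM
Compound 2 `COc1ccc(-c2cc(/C=C/C(=O)c3ccccc3)nc3cc(-c4ccccc4)nn23)cc1OC`: 11800 nM

For the measured compounds named here, in a functional assay on MDA-MB-231 cells (Homo sapiens) for antiproliferative activity, read by MTT assay, with a stated time of 24 h (on this read-out lower numbers stand for stronger inhibition and higher numbers for weaker inhibition), compound 2 gives 11800 nM, the lowest of the two numbers so far. Compound 1 gives 17100 nM, and the step of a 1.4-fold lower number from compound 1 to compound 2 (0.16 log units; within the scatter) lies within the scatter, so the two compounds are not separated by this read-out. Compound 3 `COc1cc(-c2cc(/C=C/C(=O)c3ccccc3)nc3cc(-c4ccccc4)nn23)cc(OC)c1OC` differs from compound 2 by methoxy in place of hydrogen on an aromatic carbon. Going by the values given here, no measured step touches this part of the shared core: the single step available concerns a different ring and was itself within the scatter, so it gives no direction for the change from compound 2 to compound 3. The expected step of a 1.3-fold lower number from compound 2 to compound 3 (0.12 log units; within the scatter) is therefore small and may well stay within the scatter, with a wide range to reflect the lack of any bearing step. Compound 3 is estimated at 9000 nM, between 3500 nM and 25000 nM.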

Compound 3, half-maximal inhibitory concentration: 15800 nM
The estimate for compound 3 lay 1.8-fold (0.24 log units) below the measured number; measured number inside the range.
By their numbers in this assay, from the lowest: compounds 2, 3 and 1 (each within the scatter of the next).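

In this assay, going from the 3,4-dimethoxyphenyl to the 3,4,5-trimethoxyphenyl group gives a 1.3-fold higher number from compound 2 to compound 3 (0.13 log units; within the scatter) and so does not separate the two compounds. For the compounds shown here, the only earlier step concerned chloro on a different ring, whereas this one shows that on this ring, too, a methoxy in place of hydrogen on the carbon ortho to a methoxy group leaves the read-out within the scatter. No available evidence bears on this result.

The compounds shown leave open whether a different group at this carbon, such as an amine, a hydroxyl or a carboxylic acid, would move the number beyond the scatter. They also leave open what happens when the two existing methoxy groups are replaced, since every compound shown carries both.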